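Amide variation on the shared core: tolerability notes

This account rests on a few compounds, and the source may have more. Where it says the series, first, only, none or still open, it means among the compounds named here.

Compound 1: `COc1ccc(-c2cnc(NC(=O)c3cnco3)n2C)cc1`; > 100000 nM
Compound 2: `COc1ccc(-c2cnc(NC(C)=O)n2C)cc1`; > 100000 nM
Compound 3: `COc1ccc(-c2cnc(NC(=O)c3cccc(C)c3)n2C)cc1`; > 100000 nM

The read-out throughout is a toxicity assay on THP-1 cells (Homo sapiens) for inhibition; a lower number here means that less compound is tolerated, a higher number that more compound is tolerated. Each of the three values is a limit of the assay and not a number. Compound 3 sits at that limit, and the other two compounds sit at the same limit. This is the situation summed up by the limit of > 100000 nM in this assay, at which 3 of the 3 values shown sit. The steps a step that the two limits leave unreadable from compound 1 to compound 2, a step that the two limits leave unreadable from compound 1 to compound 3 and a step that the two limits leave unreadable from compound 2 to compound 3 are therefore of no readable size, and neither a direction nor a magnitude can be taken from them.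

Compound 4 is `COc1ccc(C(=O)Nc2ncc(-c3ccc(OC)cc3)n2C)cc1`. It differs from compound 3 by 4-methoxyphenyl in place of 3-methylphenyl on a carbonyl carbon. Among the compounds with values here, the step from compound 3 to compound 4 has no measured counterpart; the only steps available, all at the carbonyl carbon, are the three unreadable ones above. With every measured amide at the limit, the expectation is that compound 4 also reaches the limit rather than a number, so the expected step of a number no higher from compound 3 to compound 4 (the limit leaves the size open) is none beyond the scatter. The estimate for compound 4 is 100000 nM, within 50000 nM to 200000 nM.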

Compound 4, half-maximal cytotoxic concentration: > 100000 nM
Compound 4 ended at the assay's limit (the forecaster's own chance of this, stated with the estimate: 85%); the middle value sits exactly at the limit.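

In this assay, within the data shown here, no step from compound 4 to compound 1, compound 2 or compound 3 can be read, as all four compounds give a limit and not a number: the limit of > 100000 nM in this assay, at which 4 of the 4 values shown sit.

The compounds shown leave open whether the group on the carbonyl carbon changes tolerance at all.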